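The source may report more compounds than this note shows. Statements on the series, on what has been measured and on what is new or still open speak of the compounds shown alone.

Working notes on the series in an ADME assay on BJ cells (Homo sapiens) for cytotoxicity, with a stated time of 72 h; a lower number here means that less compound is needed, a higher number that more compound is needed for the effect. Compound 1 `COc1ccc(-c2nc3c(c(C)nn3-c3ccccc3)c(-c3ccccc3O)c2C#N)cc1` reads > 23000 nM, which is a limit (the limit of > 23000 nM in this assay, at which 1 of the 3 values shown sits). Going by the values given here, compound 2 `Cc1ccccc1-c1nc2c(c(C)nn2-c2ccccc2)c(-c2ccccc2O)c1C#N` gives 21000 nM, the only true number so far. Compound 3 `Cc1nn(-c2ccccc2)c2nc(-c3ccc(F)cc3)c(C#N)c(-c3ccccc3O)c12` reads > 20000 nM, which is also a limit (the limit of > 20000 nM in this assay, at which 1 of the 3 values shown sits). Compound 4 `Cc1nn(-c2ccccc2)c2nc(-c3ccc([N+](=O)[O-])cc3)c(C#N)c(-c3ccccc3O)c12` carries nitro in place of fluoro on an aromatic carbon, para to a large group (nitro in place of fluoro on an aromatic carbon). The measured changes on this aryl group bear on it: an at least 1.0-fold lower number from compound 1 to compound 2 (0.03 log units; that floor lies within the scatter), a step that the two limits leave unreadable from compound 1 to compound 3 and a step that the limit leaves unreadable from compound 2 to compound 3. None shows a step beyond the scatter, so none is expected here, and the expected step is an at least 1.1-fold lower number from compound 3 to compound 4 (0.07 log units; that floor lies within the scatter). For compound 4 the estimated value is 17000 nM, with an expected range of 6000 nM to 30000 nM.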

Compound 4, half-maximal effective concentration: > 20000 nM
Compound 4 gave a limit, no number; the forecaster's own chance of this, stated with the estimate: 55%; at least 1.1-fold (0.07 log units) between middle value and limit.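

Compound 4 reads as a limit in this assay, as does compound 3: the limit of > 20000 nM in this assay, at which 2 of the 4 values shown sit. Its steps from compound 1, compound 2 and compound 3 cannot be read. The compounds shown leave open whether nitro in place of fluoro changes the number at all.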